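This account rests on a few compounds, and the source may have more. Where it says the series, first, only, none or still open, it means among the compounds named here.

Measured so far: compound 1, `Cc1ccc(Nc2nc(SCc3cn(Cc4ccccc4Cl)nn3)nc(-c3ccccc3)c2C#N)cc1`, and compound 2, `Cc1ccc(Nc2nc(SCc3cn(Cc4ccccc4Cl)nn3)nc(-c3ccc(C(C)C)cc3)c2C#N)cc1`.

In a functional assay on ECa-109 cells (Homo sapiens) for inhibition, read by MTT assay, with a stated time of 72 h (on this read-out lower numbers stand for stronger inhibition and higher numbers for weaker inhibition), compound 1 reaches only a limit of the assay, > 64000 nM. In this assay compound 2 gives 5080 nM, the only plain number shown, so compound 2 stands as the one compound with a measured value here.

The compound not yet measured is compound 3, `Cc1ccc(Nc2nc(SCc3cn(Cc4ccccc4Cl)nn3)nc(-c3ccc(C)cc3)c2C#N)cc1`. Its change from compound 2 is methyl in place of isopropyl on an aromatic carbon. Going by the values given here, only one measured step bears on this position, the step of an at least 12-fold lower number from compound 1 to compound 2 (1.10 log units; beyond the scatter), where a hydrogen at that carbon became an isopropyl and the number dropped out of the limit into a plain value. The new change goes part of the way back: the isopropyl shrinks to a methyl, but the carbon is not left bare as in compound 1. A step in this assay towards a higher number, weaker inhibition, is therefore expected, smaller than the drop seen from compound 1 to compound 2.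

Compound 3 is expected to give 15000 nM, in the range 5000 nM to 50000 nM, which would mean an estimated step of a 3.0-fold higher number from compound 2 to compound 3 (0.47 log units; beyond the scatter).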

Compound 3, half-maximal inhibitory concentration: 4650 nM
Compound 3: the middle estimate sits 3.2-fold (0.51 log units) above what was measured; the measured number lies below the stated range.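

In this assay, exchanging the isopropyl for a methyl gives a 1.1-fold lower number from compound 2 to compound 3 (0.04 log units; within the scatter), which is within the scatter, so this read-out does not separate the two groups even though the methyl has 1 heavy atom and the isopropyl has 3. The methyl alone is also enough to give an at least 13-fold lower number from compound 1 to compound 3 (1.13 log units; beyond the scatter), so among these three compounds, what matters at this carbon is whether its hydrogen is replaced, not which of these two groups replaces it. The size of that step is only a minimum, because the value for compound 1 is a limit and not a number: the limit of > 64000 nM in this assay, at which 1 of the 3 values shown sits.

The compounds shown leave open whether the effect belongs to alkyl groups alone, since a methoxy, a chlorine, an amine or a carboxylic acid on this carbon could give quite a different number. They also leave open what a longer chain, such as a butyl or a hexyl, would do at this position, and whether the flat stretch from methyl to isopropyl would continue.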